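The source may report more compounds than this note shows. Statements on the series, on what has been measured and on what is new or still open speak of the compounds shown alone.

Measured compounds:
Compound 1, `COc1ccc(CNCc2c(OC)cc(Oc3cccc(Nc4ccccc4)c3)cc2OC)cc1`: in a functional assay on SW-620 cells (Homo sapiens) for inhibition, read by MTT assay, with a stated time of 72 h (on this read-out lower numbers stand for stronger inhibition and higher numbers for weaker inhibition), compound 1 gives 6970 nM.
Compound 2, `COc1cc(Oc2cccc(Nc3ccccc3)c2)cc(OC)c1CN[C@H](C)c1ccccc1`: compound 2 gives 18700 nM.
Compound 3, `COc1cc(Oc2cccc(Nc3ccccc3)c2)cc(OC)c1CCO`: compound 3 gives only a limit of the assay, > 20000 nM.

Of the two numbers in this assay, compound 1 stands lowest; the nearest, compound 2, shows a 2.7-fold higher number from compound 1 to compound 2 (0.43 log units; beyond the scatter), a 1-phenylethyl in place of 4-methoxybenzyl on the amine nitrogen. Compound 3 sits at the assay limit (the limit of > 20000 nM in this assay, at which 1 of the 3 values shown sits). From compound 1 to compound 3 there is an at least 2.8-fold higher number from compound 1 to compound 3 (0.45 log units; beyond the scatter), and from compound 2 to compound 3 an at least 1.0-fold higher number from compound 2 to compound 3 (0.02 log units; that floor lies within the scatter).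

Compound 4, `COc1cc(Oc2cccc(Nc3ccccc3)c2)cc(OC)c1CNCc1ccc(O)cc1`, differs from compound 1 by hydrogen in place of methyl on an oxygen on an aromatic ring. Within the data shown here, no measured step touches this oxygen: both steps starting from compound 1 replace or remove the whole 4-methoxybenzyl group on the amine nitrogen, and each raised the number modestly. A change confined to the methyl on that ring is smaller than either of them, so in this assay a step of a 1.2-fold higher number from compound 1 to compound 4 (0.09 log units; within the scatter) is expected, at most a modest rise and possibly none beyond the scatter. Compound 4 is therefore estimated at 8500 nM, within 3500 nM to 19000 nM.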

Compound 4, half-maximal inhibitory concentration: 7940 nM
Compound 4: middle estimate off by 1.1-fold (0.03 log units), on the high side; the measured number falls inside the stated range.
By their numbers in this assay, from the lowest: compounds 1 and 4 (each within the scatter of the next); then compound 2. At a limit, above all of these: compound 3.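

In this assay, taking the methyl off the oxygen on the aromatic ring leaves the number unresolved from that of the parent, with a 1.1-fold higher number from compound 1 to compound 4 (0.06 log units; within the scatter), so methoxy and hydroxy cannot be told apart here. The earlier steps shown here had changed the whole group on the amine nitrogen, and the new compound shows that the gaps to the other two compounds hold with 4-hydroxybenzyl as well as with 4-methoxybenzyl: 4-hydroxybenzyl in place of 1-phenylethyl gives a 2.4-fold lower number from compound 2 to compound 4 (0.37 log units; beyond the scatter), and (4-hydroxybenzyl)amino in place of hydroxymethyl gives an at least 2.5-fold lower number from compound 3 to compound 4 (0.40 log units; beyond the scatter). The value of compound 3 is only a limit, which makes that last step a floor: the limit of > 20000 nM in this assay, at which 1 of the 4 values shown sits.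

On these data alone, it remains open whether the oxygen matters at all, since a plain benzyl on the amine nitrogen, or an amine or a carboxylic acid in place of the hydroxy, could read differently. The compounds shown also do not separate the branching methyl of 1-phenylethyl from the loss of the oxygen on the ring in accounting for the higher number of compound 2.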